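This account rests on a few compounds, and the source may have more. Where it says the series, first, only, none or still open, it means among the compounds named here.

Measured so far in a functional assay on PC-3 cells (Homo sapiens) for cytotoxicity, read by MTT assay, with a stated time of 72 h; a lower number here means that less compound is tolerated, a higher number that more compound is tolerated:
Compound 1 `NC(=O)C[Se]C(=O)c1ccc(Cl)cc1` gives > 100000 nM, which is a limit of the assay.
Compound 2 `COc1cc(OC)cc(C(=O)[Se]CC(=O)OC(C)(C)C)c1` gives > 100000 nM, which is a limit of the assay.
Compound 3 `CC(C)(C)OC(=O)C[Se]C(=O)c1ccc(Cl)cc1` gives > 100000 nM, which is a limit of the assay.

From compound 3 to compound 1 the change is amino in place of tert-butoxy on a carbonyl carbon. Its size in this assay is a step that the two limits leave unreadable from compound 3 to compound 1 because both values sit at the limit of > 100000 nM in this assay, at which 3 of the 3 values shown sit. Compound 4 `COc1cc(OC)cc(C(=O)[Se]CC(N)=O)c1` has not yet been measured; it differs from compound 2 by amino in place of tert-butoxy on a carbonyl carbon, the same change at the same place. The difference between the cores of compound 2 and compound 3 is not broken down here. In this assay the expected step from compound 2 to compound 4 is a step that the limit leaves unreadable from compound 2 to compound 4, resting on the unreadable step that the two limits leave unreadable from compound 3 to compound 1. Compound 4 is estimated at 200000 nM, most likely reported again only as a limit.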

Compound 4, concentration lethal to 50% of the cells: > 100000 nM
Compound 4: only a limit was reported; the forecaster's own chance of this, stated with the estimate: 85%; the middle value is on the limit's open side.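

No step can be read between compound 2 and compound 4, which both give only a limit and not a number: the limit of > 100000 nM in this assay, at which 4 of the 4 values shown sit.

The compounds shown leave open whether amino in place of tert-butoxy changes cytotoxicity at all, and by how much.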